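Cytotoxicity series: aryl substituent swap at the isoxazole phenyl

This account rests on a few compounds, and the source may have more. Where it says the series, first, only, none or still open, it means among the compounds named here.

Measured so far:
compound 1 `O=[N+]([O-])c1ccc(CN2CCC(n3cc(CC(OCc4cc(-c5ccc(Br)cc5)no4)c4ccc(Br)cc4)nn3)CC2)cc1` — 3000 nM
compound 2 `O=[N+]([O-])c1ccc(CN2CCC(n3cc(CC(OCc4cc(-c5ccc(F)cc5)no4)c4ccc(Br)cc4)nn3)CC2)cc1` — 3000 nM

In a functional assay on Caco-2 cells (Homo sapiens) for cytotoxicity, with a stated time of 48 h (a higher number here means a weaker inhibitor, a lower number a stronger inhibitor), compound 1 gives 3000 nM. Compound 2 stands level with compound 1 at the digits shown, since the step of no change at the digits printed from compound 1 to compound 2 (within the scatter) lies within the scatter. Compound 3 `COc1ccc(-c2cc(COC(Cc3cn(C4CCN(Cc5ccc([N+](=O)[O-])cc5)CC4)nn3)c3ccc(Br)cc3)on2)cc1` is not yet measured in this assay. It differs from compound 2 by methoxy in place of fluoro on an aromatic carbon. Going by the values given here, only one measured step bears on this position: the swap from bromo to fluoro, no change at the digits printed from compound 1 to compound 2 (within the scatter), which produced no change beyond the scatter. Among the compounds with values here, nothing measured shows what a methoxy group does at this carbon, so the expectation rests on the single neighbouring step. On that basis no step beyond the scatter is expected for compound 3, no change at the digits printed from compound 2 to compound 3 (within the scatter). The estimate for compound 3 in this assay is therefore 3000 nM, with a range from 1200 nM to 7500 nM.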

Compound 3, half-maximal inhibitory concentration: 3000 nM
Beside the measured number, compound 3's estimate shows no gap at the digits printed, within the range that was stated.
By their numbers in this assay, from the lowest: compounds 1, 2 and 3 (each within the scatter of the next).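

At the carbon para to a large group, this assay gives no change at the digits printed from compound 2 to compound 3 (within the scatter) for methoxy in place of fluoro and no change at the digits printed from compound 1 to compound 3 (within the scatter) for methoxy in place of bromo. The earlier pair covered only two halogens, whereas this position now also carries a group entering through oxygen, with two heavy atoms and one hydrogen-bond acceptor, and the read-out still does not separate the three compounds.

Open, on these data alone, is whether an amine or a carboxylic acid at this carbon would move the value beyond the scatter. A longer chain such as butoxy in place of methoxy also stays untested among the compounds shown, so the tolerance seen here holds only for bromo, fluoro and methoxy. No outside data bear on this result.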